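Isobutyl in place of the dimethoxy group on compound 2

The source may hold more compounds than are shown below. What is called first, only, known or untested is meant among the compounds shown, and "the series" means these compounds.

Measured so far in a functional assay on HT-22 cells (Mus musculus), read by LDH release; a lower number here means that less compound is tolerated, a higher number that more compound is tolerated 
compound 1 `CN(CC1OCCO1)C1Oc2ccc(C(=O)c3ccccc3)c(O)c2NC1c1ccccc1` gives > 250 uM as a limit
compound 2 `COC(CNC1Oc2ccc(C(=O)c3ccccc3)c(O)c2NC1c1ccccc1)OC` gives > 250 uM as a limit

Compound 2 stands at a limit and has no number. Going by the values given here, the only other value, for compound 1, is a limit as well, so the series so far reads as the limit of > 250 uM in this assay, at which 2 of the 2 values shown sit, and offers no measured spread.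

Compound 3 `CC(C)CNC1Oc2ccc(C(=O)c3ccccc3)c(O)c2NC1c1ccccc1` is the next entry. Its difference from compound 2 is isopropyl in place of dimethoxymethyl on a saturated chain carbon bound to an amine nitrogen. The same change reads as 2,2-dimethoxyethyl to isobutyl.

Among the compounds with values here, one measured step bears on this, a step that the two limits leave unreadable from compound 1 to compound 2, and it has no size to carry over. No direction can be argued from it, so the expectation is for no step beyond the scatter in this assay and rests only on the limit of > 250 uM in this assay, at which 2 of the 2 values shown sit, as the sole reference. The expected change is a number no higher from compound 2 to compound 3 (the limit leaves the size open) and no more can be said of it. For compound 3 the estimated value is 250 uM with an expected range from 100 uM to 500 uM and a good chance of a limit in place of a number.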

Compound 3, half-maximal toxic concentration: 79 uM
Estimate against measurement, compound 3: 3.2-fold (0.50 log units) above, and the stated range ends above it.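

In this assay, isopropyl in place of dimethoxymethyl on a saturated chain carbon bound to an amine nitrogen gives an at least 3.1-fold lower number from compound 2 to compound 3 (0.50 log units; beyond the scatter), so this position can shift the tolerated concentration, which the earlier pair could not show. The same drop appears against the other parent, with isobutylamino in place of ((1,3-dioxolan-2-yl)methyl)(methyl)amino on a saturated ring carbon giving an at least 3.1-fold lower number from compound 1 to compound 3 (0.50 log units; beyond the scatter), although this change also removes the methyl group on the amine nitrogen and the ring of the leaving group. Compound 1 and compound 2 both stay at a limit, so the step between them cannot be read and the two new steps fix only a minimum size: the limit of > 250 uM in this assay, at which 2 of the 3 values shown sit.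

Nothing shown separates the loss of the oxygen atoms of dimethoxymethyl from the change in the size of the group, since isopropyl differs from it in both. A 2-methoxyethyl group or a longer chain such as 3-methylbutyl on the same amine nitrogen would bear on that question, and a carboxylic acid at the end of the chain would test whether the number recovers.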